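Aryl change on the triazole nitrogen of the spiro series

The source may hold more compounds than are shown below. What is called first, only, known or untested is meant among the compounds shown, and "the series" means these compounds.

Measured so far:
compound 1 `N#CC1=C(N)Oc2c(N)cc3nc4ccccc4nc3c2C12C(=O)N(Cc1cnnn1-c1ccc(F)cc1)c1ccccc12` — > 50000 nM
compound 2 `N#CC1=C(N)Oc2c(N)cc3nc4ccccc4nc3c2C12C(=O)N(Cc1cnnn1-c1c(F)cccc1F)c1ccccc12` — > 50000 nM

Both compounds share one core and differ only in the aryl group on the aromatic nitrogen of the five-membered aromatic ring with 3 nitrogen. In a functional assay on HepG2 cells (Homo sapiens) for antiproliferative activity, read by MTT assay, with a stated time of 48 h (on this read-out higher numbers stand for weaker inhibition and lower numbers for stronger inhibition), compound 1 gives only a limit, > 50000 nM. Compound 2 also reaches only the limit of this assay, > 50000 nM. Going by the values given here, the one step that joins them, a step that the two limits leave unreadable from compound 1 to compound 2, stays unreadable because both values sit at the limit of > 50000 nM in this assay, at which 2 of the 2 values shown sit.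

Compound 3 `N#CC1=C(N)Oc2c(N)cc3nc4ccccc4nc3c2C12C(=O)N(Cc1cnnn1-c1ccc(Cl)cc1[N+](=O)[O-])c1ccccc12` is not yet measured. It differs from compound 2 by 4-chloro-2-nitrophenyl in place of 2,6-difluorophenyl on an aromatic nitrogen. Among the compounds with values here, the only measured step at this position bears on it, and that step has no readable size or direction, so the record gives no ground for expecting a gain or a loss in this assay. Compound 3 is therefore expected to remain at or near the limit, estimated at 70000 nM with a range from 20000 nM to 250000 nM. The step this estimate implies is a step that the limit leaves unreadable from compound 2 to compound 3, expected to lie inside the unreadable region rather than beyond the scatter.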

Compound 3, half-maximal inhibitory concentration: > 50000 nM
Compound 3: only a limit was reported; the forecaster's own chance of this, stated with the estimate: 75%; the middle value is on the limit's open side.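

In this assay compound 3 gives > 50000 nM, a limit of the assay and not a number. No step among compound 1, compound 2 and compound 3 can be read, and none has a size or direction: the limit of > 50000 nM in this assay, at which 3 of the 3 values shown sit.

On these data alone, whether any aryl group on this aromatic nitrogen of the shared core gives a readable value remains open.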